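This account rests on a few compounds, and the source may have more. Where it says the series, first, only, none or still open, it means among the compounds named here.

Among the compounds with values here, in a functional assay on CHO cells for antagonist activity at Orexin/Hypocretin receptor type 1 (Homo sapiens), read by FLIPR and calcium flux (a lower number here means a stronger inhibitor, a higher number a weaker inhibitor), compound 2, `Cc1occc1-c1nnc(SCC(=O)Nc2ccc(F)c(Cl)c2)n1Cc1ccco1`, gives 1000 nM, the only value among the three measured compounds that is a number rather than a limit. Compound 1, `Cc1cccc(NC(=O)CSc2nnc(-c3ccoc3C)n2Cc2ccco2)c1C`, reaches only the limit > 15800 nM in this assay. Compound 3, `Cc1occc1-c1nnc(SCC(=O)Nc2cccc(F)c2)n1Cc1ccco1`, likewise gives only the limit > 15800 nM in this assay. The two measured steps that leave compound 2 both change the group on the amide-type nitrogen: an at least 15-fold lower number from compound 1 to compound 2 (1.19 log units; beyond the scatter) and an at least 15-fold higher number from compound 2 to compound 3 (1.19 log units; beyond the scatter), each bounded by the limit of > 15800 nM in this assay, at which 2 of the 3 values shown sit. Compound 4, `CC(=O)c1ccc(NC(=O)CSc2nnc(-c3ccoc3C)n2Cc2ccco2)cc1`, carries a further change at the same position: 4-acetylphenyl in place of 3-chloro-4-fluorophenyl on an amide-type nitrogen. Within the data shown here, no measured step tests this group, but every departure from 3-chloro-4-fluorophenyl seen so far in this assay has gone to a limit. Compound 4 is therefore expected to be weaker, with a step of an 8.0-fold higher number from compound 2 to compound 4 (0.90 log units; beyond the scatter) in this assay. The estimate for compound 4 is 8000 nM, within a range from 1500 nM to 30000 nM, with a fair chance that only a limit is reported.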

Compound 4, inhibition constant: 2510 nM
Compound 4: the middle estimate sits 3.2-fold (0.50 log units) above what was measured; low and high end bracket the measured number.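

In this assay, a departure from 3-chloro-4-fluorophenyl on the amide-type nitrogen need not end at a limit: 4-acetylphenyl, which carries neither chlorine nor fluorine, still gives a measurable number, with a 2.5-fold higher number from compound 2 to compound 4 (0.40 log units; beyond the scatter). The same group also separates clearly from the other two aryl groups, with an at least 6.2-fold lower number from compound 3 to compound 4 (0.79 log units; beyond the scatter) and an at least 6.2-fold lower number from compound 1 to compound 4 (0.79 log units; beyond the scatter). The true size of these last two steps stays unknown, as each is bounded by a limit rather than a number: the limit of > 15800 nM in this assay, at which 2 of the 4 values shown sit.

The compounds shown leave open whether the acetyl group itself accounts for the difference, or whether a nitrile, a carboxylic acid or an amine in its place would serve as well. Going by these compounds, all four compounds share the same core, so the effect of a change anywhere else also remains open.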